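Extending the amine arm of a cyclopropanecarboxamide GPR88 agonist

A few compounds are considered here, and "the series" means these few. Any claim that something is new, unique, unknown or untested is made for them only; others in the source may bear on it.

Compound 2 `CC(C)(N)CN(C(=O)[C@@H]1C[C@H]1c1ccccc1)c1ccc(-c2ccccc2)cc1` gives 1.4 nM in a functional assay for agonist activity at G protein-coupled receptor 88 (Homo sapiens), read by HTRF and cAMP accumulation (a lower number here means that less compound is needed, a higher number that more compound is needed for the effect), the lowest of the two numbers recorded, with compound 1 `CC(C)C[C@@H](N)CN(C(=O)[C@@H]1C[C@H]1c1ccccc1)c1ccc(-c2ccccc2)cc1` nearest at 1.8 nM; the step of a 1.3-fold lower number from compound 1 to compound 2 (0.11 log units; within the scatter) keeps the two within the scatter of each other. Compound 3 `O=C([C@@H]1C[C@H]1c1ccccc1)N(CCNCC1CCCC1)c1ccc(-c2ccccc2)cc1` has not yet been measured. It differs from compound 2 by ((cyclopentylmethyl)amino)methyl in place of 1-amino-1-methylethyl on a saturated chain carbon bound to an amide-type nitrogen. Among the compounds with values here, the only step that bears on this position is a 1.3-fold lower number from compound 1 to compound 2 (0.11 log units; within the scatter), which shows that exchanging one branch for another on the same saturated chain carbon left the number essentially unchanged. Within the data shown here, that step, however, kept the amine in place and only altered the carbon substituents, whereas the change to compound 3 removes the two methyl groups and puts a cyclopentylmethyl group onto the nitrogen itself; no measured pair speaks to that. Compound 3 is therefore expected to stay in the same potency region with a modest loss, the expected step being a 5.7-fold higher number from compound 2 to compound 3 (0.76 log units; beyond the scatter). The estimated value of compound 3 in this assay is 8 nM, with an expected range from 1.5 nM to 50 nM.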

Compound 3, half-maximal effective concentration: 2.5 nM
For compound 3 the middle estimate is 3.2-fold (0.51 log units) above the measured one; low and high end bracket the measured number.
By their numbers in this assay, from the lowest: compounds 2, 1 and 3 (each within the scatter of the next).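

In this assay, putting ((cyclopentylmethyl)amino)methyl in place of 1-amino-1-methylethyl gives a 1.8-fold higher number from compound 2 to compound 3 (0.25 log units; within the scatter), and putting it in place of 1-amino-3-methylbutyl gives a 1.4-fold higher number from compound 1 to compound 3 (0.14 log units; within the scatter). The earlier step had only exchanged carbon branches around an unsubstituted amine, whereas these steps show that this place, on a saturated chain carbon bound to an amide-type nitrogen, also accepts a cyclopentylmethyl group on the amine nitrogen, with 8 heavy atoms entering where 4 leave, and that all three compounds remain within the scatter of each other. Nothing available explains why the number holds across this change.

Because the two methyl groups go and the cyclopentylmethyl group arrives in the same step, the compounds shown do not separate the two parts of the change, which a plain 2-aminoethyl arm would help to divide. They also leave open how far the arm tolerates other groups on the nitrogen, such as a cyclohexylmethyl or a benzyl group, and whether the amine itself is needed at all, as a hydroxyl group in its place would test.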